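Cytotoxicity in PC-3 cells: from sulfonamide to aryl amine

The compounds below may be only part of what the source reports. "The series", "measured", "known", "first", "only" and "open" are said of these compounds alone.

Three compounds sharing one core have been examined so far. Compound 1 `C[C@@H](Cn1ccc(-c2ccc(C#N)c(Cl)c2)n1)NC(=O)c1ccccc1` gave a value in an ADME assay on PC-3 cells (Homo sapiens) for cytotoxicity, read by CCK-8 assay, with a stated time of 6 days (a lower number here means a stronger inhibitor, a higher number a weaker inhibitor), that is a limit of the assay, > 30000 nM. Compound 2 `C[C@@H](Cn1ccc(-c2ccc(C#N)c(Cl)c2)n1)NC(=O)c1ccccc1F` likewise gave only a limit in this assay, > 30000 nM. Compound 3 `C[C@@H](Cn1ccc(-c2ccc(C#N)c(Cl)c2)n1)NS(=O)(=O)c1cccnc1` also reached only a limit in this assay, > 30000 nM. Among the measured compounds shown here, compound 3 therefore stands at the limit of > 30000 nM in this assay, at which 3 of the 3 values shown sit, and none of the measured steps can be read: a step that the two limits leave unreadable from compound 1 to compound 2, a step that the two limits leave unreadable from compound 1 to compound 3, and a step that the two limits leave unreadable from compound 2 to compound 3.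

Compound 4 `C[C@@H](Cn1ccc(-c2ccc(C#N)c(Cl)c2)n1)Nc1cccnc1` differs from compound 3 in one place: pyridin-3-yl in place of (pyridin-3-yl)sulfonyl on an amine nitrogen. For the measured compounds named here, no measured step touches this exchange, and the steps that exist are all unreadable, so the data offer no direction for the expected size of a step that the limit leaves unreadable from compound 3 to compound 4. With every value resting at the limit, compound 4 is estimated to give 40000 nM in this assay, within a range from 10000 nM to 150000 nM, most likely again as a limit rather than a number.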

Compound 4, half-maximal inhibitory concentration: > 30000 nM
Compound 4: no number, only a limit; the forecaster's own chance of this, stated with the estimate: 80%; the middle value lies beyond the limit too.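

In this assay compound 4 gives > 30000 nM, again a limit of the assay. Its steps from compound 1, compound 2 and compound 3 therefore cannot be read: the limit of > 30000 nM in this assay, at which 4 of the 4 values shown sit.

The compounds shown leave open whether any exchange on the amine nitrogen shifts the value in this assay at all, and in which direction.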